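The source may report more compounds than this note shows. Statements on the series, on what has been measured and on what is new or still open speak of the compounds shown alone.

Measured compounds:
compound 1, `Cc1ccc(-c2nn(-c3ccccc3)cc2C(=O)NC(=S)Nc2ccc(Cl)cc2)cc1`, in a functional assay on NCI-H460 cells (Homo sapiens) for inhibition, read by CCK-8 assay, with a stated time of 48 h (on this read-out higher numbers stand for weaker inhibition and lower numbers for stronger inhibition), gives 3650 nM
compound 2, `O=C(NC(=S)Nc1ccc(F)cc1)c1cn(-c2ccccc2)nc1-c1ccc(F)cc1`, in this assay gives 3240 nM
compound 3, `O=C(NC(=S)Nc1ccc(F)cc1)c1cn(-c2ccccc2)nc1-c1ccc(Cl)cc1`, in this assay gives 3640 nM

Compound 3 stands second highest of the three numbers, yet all three lie within the scatter of one another, so no order among them can be claimed. Among the measured compounds shown here, the one step that can be read directly, a 1.1-fold higher number from compound 2 to compound 3 (0.05 log units; within the scatter), changes chloro for fluoro on the aromatic carbon para to a large group and moves the number by no more than the scatter.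

Compound 4, `Cc1ccc(-c2nn(-c3ccccc3)cc2C(=O)NC(=S)Nc2ccc(F)cc2)cc1`, is not yet measured. It differs from compound 3 by methyl in place of chloro on an aromatic carbon, at the same place where the step from compound 2 to compound 3 was made. That step was within the scatter, and compound 1, which carries the same methylphenyl group as compound 4 but chloro instead of fluoro on the other aromatic ring, sits within the scatter of compound 3 as well. Nothing in the measured set therefore points to a move beyond the scatter in this assay in either direction; the step is expected to be a 1.0-fold lower number from compound 3 to compound 4 (0.02 log units; within the scatter). Compound 4 is accordingly estimated at 3500 nM, with a range from 2000 nM to 6500 nM.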

Compound 4, half-maximal inhibitory concentration: 3980 nM
Compound 4: middle estimate off by 1.1-fold (0.06 log units), on the low side; measured number inside the range.
By their numbers in this assay, from the lowest: compounds 2, 3, 1 and 4 (each within the scatter of the next).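

Methyl at this place gives a 1.1-fold higher number from compound 3 to compound 4 (0.04 log units; within the scatter) and a 1.2-fold higher number from compound 2 to compound 4 (0.09 log units; within the scatter), so in this assay the place now tolerates a carbon group as well as the two halogens, where the earlier compounds had compared only fluoro and chloro. The 4-chlorophenyl to 4-methylphenyl change therefore leaves the number within the scatter, and none of the three groups can be set above another. The new compound also completes a matched pair, a 1.1-fold higher number from compound 1 to compound 4 (0.04 log units; within the scatter), so the exchange of chloro and fluoro can now be read on two cores, and it stays small on both: the same change on two cores in this assay, a 1.1-fold higher number (0.05 log units; within the scatter) from compound 2 to compound 3 and a 1.1-fold lower number (0.04 log units; within the scatter) from compound 4 to compound 1, 1.2-fold (0.09 log units) apart, within the scatter of two such steps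

On these data alone, what an amine, a carboxylic acid or a longer chain would do at this place in this assay stays open, as does whether any group there can move the number beyond the scatter. Whether the same flat picture holds in any other cell line also remains open, as all four compounds are shown in this one assay alone.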